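The compounds below may be only part of what the source reports. "The series", "measured", "known", "first", "only" and "open" are said of these compounds alone.

Three compounds share one core. Compound 1 `CC(=O)N/N=C/c1c(Cl)n(C2O[C@H](CO)[C@@H](O)[C@H]2O)c2cc(Cl)c(Cl)cc12` carries an acetyl hydrazone, and in a functional assay on KB cells (Homo sapiens) for cytotoxicity, read by spectrophotometry and crystal violet staining (on this read-out higher numbers stand for weaker inhibition and lower numbers for stronger inhibition), compound 1 gives 9000 nM. Compound 2 `N/C(=N\O)c1c(Cl)n(C2O[C@H](CO)[C@@H](O)[C@H]2O)c2cc(Cl)c(Cl)cc12` in this assay gives > 100000 nM, which is a limit of the assay rather than a number. Compound 3 `OC[C@H]1O[C@@H](n2c(Br)nc3cc(Cl)c(Cl)cc32)[C@H](O)[C@@H]1O` in this assay also reaches only a limit, > 100000 nM. Within the data shown here, the single step that joins measured compounds, an at least 11-fold higher number from compound 1 to compound 2 (1.04 log units; beyond the scatter), is large, and the limit of > 100000 nM in this assay, at which 2 of the 3 values shown sit, marks where compound 2 stands, at the top of the values shown. Compound 4 `CN(C)/N=C/c1c(Cl)n(C2O[C@H](CO)[C@@H](O)[C@H]2O)c2cc(Cl)c(Cl)cc12` differs from compound 2 by a group of 5 heavy atoms (3 carbon, 2 nitrogen; no ring) in place of a group of 4 heavy atoms (1 carbon, 2 nitrogen, 1 oxygen; no ring), on an aromatic carbon, which restores a hydrazone arrangement resembling that in compound 1. The step of an at least 3.3-fold lower number from compound 2 to compound 4 (0.52 log units; beyond the scatter) is expected, since compound 1 sits at 9000 nM. Compound 4 is therefore estimated at 30000 nM, between 8000 nM and 120000 nM.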

Compound 4, half-maximal inhibitory concentration: 70000 nM
Beside the measured number, compound 4's estimate is 2.3-fold (0.37 log units) below it; the measured number falls inside the stated range.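

Keeping the hydrazone arrangement does not preserve the number of compound 1: dimethylamino in place of acetamido on the double-bonded nitrogen gives a 7.8-fold higher number from compound 1 to compound 4 (0.89 log units; beyond the scatter). The change from the other side reads only as an at least 1.4-fold lower number from compound 2 to compound 4 (0.15 log units; that floor lies within the scatter), so no real gain over compound 2 is established. Compound 2 gives a limit of the assay, not a number: the limit of > 100000 nM in this assay, at which 2 of the 4 values shown sit.

From the compounds shown here alone, it remains open whether a longer acyl chain such as propionamido, or a plain amine on the double-bonded nitrogen, would give a number closer to that of compound 1.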